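The compounds below may be only part of what the source reports. "The series", "measured", "known", "first", "only" and "open" are said of these compounds alone.

Within the data shown here, compound 3 `COc1cc(-c2nn(-c3cccc(NC(=O)Nc4ccc(Cl)c(C(F)(F)F)c4)c3)cc2-c2ccncc2)ccc1Cl`, which in a functional assay on BT-549 cells (Homo sapiens) for inhibition, read by sulforhodamine B assay, with a stated time of 48 h (on this read-out higher numbers stand for weaker inhibition of growth and lower numbers for stronger inhibition of growth), gives 10200 nM, stands second highest of the three numbers measured so far. Compound 1 `COc1cc(-c2nn(-c3cccc(NC(=O)Nc4ccc(Cl)c(Cl)c4)c3)cc2-c2ccncc2)ccc1Cl` gives 27600 nM and compound 2 `COc1cc(-c2nn(-c3cccc(NC(=O)Nc4cccc(C(F)(F)F)c4)c3)cc2-c2ccncc2)ccc1Cl` gives 3810 nM. The steps recorded all alter the aryl group on the urea: a 7.2-fold lower number from compound 1 to compound 2 (0.86 log units; beyond the scatter), a 2.7-fold lower number from compound 1 to compound 3 (0.43 log units; beyond the scatter) and a 2.7-fold higher number from compound 2 to compound 3 (0.43 log units; beyond the scatter), each modest. Among the measured compounds shown here, compound 4 `COc1cc(-c2nn(-c3cccc(NC(=O)c4ccccc4)c3)cc2-c2ccncc2)ccc1Cl` differs from compound 3 by phenyl in place of (4-chloro-3-(trifluoromethyl)phenyl)amino on a carbonyl carbon, so the urea becomes a benzamide; no measured step bears on this change directly, and the urea-aryl steps only show that variation near this position moves the number modestly. A modest step in either direction, not far beyond the scatter, is therefore expected, a 1.5-fold higher number from compound 3 to compound 4 (0.17 log units; within the scatter). Compound 4 is estimated at 15000 nM, between 4000 nM and 60000 nM.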

Compound 4, concentration for total growth inhibition: > 100000 nM
Compound 4 was reported as a limit; the forecaster's own chance of this, stated with the estimate: 15%; middle value at least 6.6-fold (0.82 log units) away from the limit.
By their numbers in this assay, from the lowest: compound 2; then compound 3; then compound 1. At a limit, above all of these: compound 4.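

In this assay compound 4 is reported as a limit and not as a number: the limit of > 100000 nM in this assay, at which 1 of the 4 values shown sits. Phenyl in place of the arylamino group on the carbonyl carbon gives an at least 9.8-fold higher number from compound 3 to compound 4 (0.99 log units; beyond the scatter) and an at least 26-fold higher number from compound 2 to compound 4 (1.41 log units; beyond the scatter) and an at least 3.6-fold higher number from compound 1 to compound 4 (0.55 log units; beyond the scatter) as its steps. The earlier changes to the urea aryl group all left numbers below this limit, so this replacement matters more than any substituent swap shown.

Compound 4 loses the amide-type nitrogen with its hydrogen and the aryl substituents together, and these two changes cannot be separated here. Going by these compounds, how a morpholine or a carboxylic acid on the carbonyl carbon would read stays open.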